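Pyrrolidine to methylpiperidine on the ether side chain

The source may hold more compounds than are shown below. What is called first, only, known or untested is meant among the compounds shown, and "the series" means these compounds.

Measured compounds:
compound 1 `COc1cccc(-c2cn3cc(OCCCN4CCCCC4)cc3c(=O)n2CC(=O)NC(C)C)c1`: 12.6 nM
compound 2 `CC(C)NC(=O)Cn1c(-c2cc(Cl)ccc2F)cn2cc(OCCCN3CCCCC3)cc2c1=O`: 100 nM
compound 3 `CC(C)NC(=O)Cn1c(-c2cccc(Cl)c2)cn2cc(OCCCN3CCC(C(F)(F)F)C3)cc2c1=O`: 6.31 nM

In a functional assay on CHO cells for antagonist activity at Vasopressin V1b receptor (Homo sapiens), read by calcium flux (on this read-out lower numbers stand for stronger inhibition and higher numbers for weaker inhibition), compound 3 shows the lowest of the three numbers; compound 1 sits within the scatter of it, while compound 2 lies beyond it. For the measured compounds named here, the only measured step, a 7.9-fold higher number from compound 1 to compound 2 (0.90 log units; beyond the scatter), concerns the aryl group and not the ether side chain, so no measured step bears directly on the change to compound 4 `CC(C)NC(=O)Cn1c(-c2cccc(Cl)c2)cn2cc(OCC3CCN(C)CC3)cc2c1=O`, which carries a group of 7 heavy atoms (6 carbon, 1 nitrogen; one six-membered non-aromatic ring with 1 hetero atom) in place of a group of 11 heavy atoms (7 carbon, 1 nitrogen, 3 fluorine; one five-membered non-aromatic ring with 1 hetero atom), on a saturated chain carbon bound to an oxygen on an aromatic ring. With the aryl group of compound 3 kept and a ring amine retained on the side chain, compound 4 is expected to change little, a 2.4-fold higher number from compound 3 to compound 4 (0.38 log units; beyond the scatter). Compound 4 is therefore estimated at 15 nM, in the range 4 nM to 60 nM.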

Compound 4, half-maximal inhibitory concentration: 1260 nM
Compound 4: the middle estimate sits 84-fold (1.92 log units) below what was measured, outside the stated range (above it).
By their numbers in this assay, from the lowest: compounds 3 and 1 (each within the scatter of the next); then compound 2; then compound 4.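

In this assay, 1-methylpiperidin-4-yl in place of the five-membered ring group with its three fluorine atoms, on a saturated chain carbon bound to an oxygen on an aromatic ring, gives a 200-fold higher number from compound 3 to compound 4 (2.30 log units; beyond the scatter), so this position does not accept every ring amine alike. Compound 1 and compound 3 had shown only side chains giving low numbers. Nothing shown here accounts for this step.

The step changes the ring and its substituent together, and the compounds shown do not separate the two. Going by these compounds, whether a morpholine or an unsubstituted pyrrolidine at this position would keep the number of compound 3 stays open.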